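The compounds below may be only part of what the source reports. "The series", "measured", "known", "first", "only" and "open" are said of these compounds alone.

Compound 2 `Cc1ncccc1-c1ccc(-c2nnc(N(C)Cc3ccc4nccn4c3)o2)cc1` gives 50.1 nM in an assay on isolated protein for inhibition of tyrosine-protein kinase Mer (Homo sapiens), read by LC-MS; a lower number here means a stronger inhibitor, a higher number a weaker inhibitor. Of the two numbers measured there, this is the larger, but it is separated from compound 1 `COc1ccccc1-c1ccc(-c2nnc(N(C)Cc3ccc4nccn4c3)o2)cc1` only by a 1.6-fold higher number from compound 1 to compound 2 (0.20 log units; within the scatter), a gap that the scatter of this assay covers. Compound 1 itself gives 31.6 nM in this assay. Compound 3 `Cc1nn(C)c(C)c1-c1ccc(-c2nnc(N(C)Cc3ccc4nccn4c3)o2)cc1` has not yet been measured; it differs from compound 2 in that (1,3,5-trimethyl-1H-pyrazol-4-yl in place of 2-methylpyridin-3-yl on an aromatic carbon). Among the measured compounds shown here, the only measured step at this position is the one from compound 1 to compound 2, which stayed within the scatter, so the single exchange of one small aromatic group for another on that carbon has so far left the number essentially where it was. Compound 3 is therefore expected to lie close to compound 2, with an estimated step of a 1.3-fold higher number from compound 2 to compound 3 (0.10 log units; within the scatter) in this assay. The estimate for compound 3 in this assay is 63 nM, with a range from 25 nM to 160 nM.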

Compound 3, half-maximal inhibitory concentration: 31.6 nM
Estimate against measurement, compound 3: 2.0-fold (0.30 log units) above; low and high end bracket the measured number.
By their numbers in this assay, from the lowest: compounds 1, 3 and 2 (each within the scatter of the next).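

In this assay, the 1,3,5-trimethyl-1H-pyrazol-4-yl group, on the aromatic carbon para to a large group, gives a 1.6-fold lower number from compound 2 to compound 3 (0.20 log units; within the scatter) and no change at the digits printed from compound 1 to compound 3 (within the scatter). The earlier compounds shown here carried only six-membered aromatic rings at this place, so this result extends the flat picture to a five-membered aromatic ring with 2 hetero atoms and three methyl groups, and all three numbers remain within the scatter of one another. Nothing available offers an explanation for this insensitivity to the exchange.

As far as these compounds go, all three compounds carry an aromatic ring on this carbon, so it remains open whether a saturated ring amine such as morpholine, a carboxylic acid or a plain hydrogen would hold the number there. From the compounds shown here alone, the shared core is identical throughout, so the effect of changing any other part of it also remains open.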